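Phenylsulfonyl in place of carbonyl: compound 3

The source may hold more compounds than are shown below. What is called first, only, known or untested is meant among the compounds shown, and "the series" means these compounds.

Among the measured compounds shown here, in a functional assay on KB cells (Homo sapiens) for antiproliferative activity, read by MTT assay, with a stated time of 72 h (a higher number here means a weaker inhibitor, a lower number a stronger inhibitor), compound 1 (`CN(C(=O)c1ccc(F)cc1)c1ccc2[nH]c(-c3n[nH]c4ccccc34)cc2n1`) gives 7220 nM as the lowest of the two numbers so far. Compound 2 (`CN(C(=O)c1ccccc1)c1ccc2[nH]c(-c3n[nH]c4cc(C#N)ccc34)cc2n1`) gives 20900 nM and stands beyond the scatter from compound 1. Compound 3 (`CN(c1ccc2[nH]c(-c3n[nH]c4ccccc34)cc2n1)S(=O)(=O)c1ccccc1`) carries phenylsulfonyl in place of (4-fluorophenyl)carbonyl on a nitrogen on an aromatic ring. For the measured compounds named here, no measured pair isolates this change, so only a modest rise in the number is expected in this assay and it may stay within the scatter. The estimated step (a 1.4-fold higher number from compound 1 to compound 3 (0.14 log units; within the scatter)) is therefore small. In this assay compound 3 is estimated at 10000 nM with an expected range of 3000 nM to 35000 nM at this stage.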

Compound 3, half-maximal inhibitory concentration: 2400 nM
Beside the measured number, compound 3's estimate is 4.2-fold (0.62 log units) above it; the whole stated range lies above it.
By their numbers in this assay, from the lowest: compound 3; then compound 1; then compound 2.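

On the nitrogen on an aromatic ring, phenylsulfonyl in place of (4-fluorophenyl)carbonyl gives a 3.0-fold lower number from compound 1 to compound 3 (0.48 log units; beyond the scatter) in this assay, so a carbonyl is not required at this position for activity. The change also removes the fluorine, so the step cannot be divided between the sulfonyl and the loss of fluorine. No available evidence bears on the origin of this step.

Still open, on these data alone, is whether (4-fluorophenyl)sulfonyl would separate these two contributions. As far as these compounds go, the effect of methylsulfonyl, or of an amine on the phenyl ring, at this nitrogen also remains open.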